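Sulfonyl to carbonyl on the shared core: compound 3

The compounds below may be only part of what the source reports. "The series", "measured", "known", "first", "only" and "open" are said of these compounds alone.

Compound 1 `COc1cc(N(Cc2nc3ccccc3[nH]2)S(=O)(=O)c2ccc(Br)cc2)cc(OC)c1OC` is the reference point of this short series. Going by the values given here, in a functional assay on MGC-803 cells (Homo sapiens) for inhibition, read by MTT assay, with a stated time of 48 h (a higher number here means a weaker inhibitor, a lower number a stronger inhibitor), compound 1 gives 2190 nM, the lowest of the two numbers measured so far. Among the compounds with values here, its only neighbour is compound 2 `COc1cc(N(Cc2nc3ccccc3[nH]2)S(=O)(=O)c2ccc(C(C)(C)C)cc2)cc(OC)c1OC`, which in this assay gives 24100 nM; the single step measured, an 11-fold higher number from compound 1 to compound 2 (1.04 log units; beyond the scatter), swaps tert-butyl for bromo on the aromatic carbon and shows that the terminus of the aryl group carries weight.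

Compound 3 `COc1cc(N(Cc2nc3ccccc3[nH]2)C(=O)c2ccc(C)cc2)cc(OC)c1OC` is not yet measured. It differs from compound 1 as (4-methylphenyl)carbonyl in place of (4-bromophenyl)sulfonyl on a nitrogen on an aromatic ring. Within the data shown here, no measured step touches the link between the nitrogen and the aryl group, so the change of sulfonyl to carbonyl has no direct precedent here; the step from compound 1 to compound 2 bears only on the group at the far end of the ring, and it was large. The combined change is therefore expected to move the number in this assay upward, by a step of a 3.0-fold higher number from compound 1 to compound 3 (0.47 log units; beyond the scatter), with wide uncertainty. For compound 3 the estimate in this assay is 6500 nM, within a range from 1500 nM to 30000 nM.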

Compound 3, half-maximal inhibitory concentration: 30500 nM
For compound 3 the middle estimate is 4.7-fold (0.67 log units) below the measured one; the measured number lies above the stated range.
By their numbers in this assay, from the lowest: compound 1; then compounds 2 and 3 (each within the scatter of the next).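

Replacing the whole (4-bromophenyl)sulfonyl group on a nitrogen on an aromatic ring gives, in this assay, a 14-fold higher number from compound 1 to compound 3 (1.14 log units; beyond the scatter), so this position also responds strongly to a change that reaches beyond the far end of the aryl group, which an 11-fold higher number from compound 1 to compound 2 (1.04 log units; beyond the scatter) could not show. Compound 1 keeps the lowest number, and both replacements read so far raise the number beyond the scatter, with no compound shown going against this; the pattern rests on only these two steps, and the new one changes the link and the ring substituent together. Nothing measured on this series explains the rise.

This step puts carbonyl in place of sulfonyl and methyl in place of bromo at once, and the data do not separate the two changes. A (4-bromophenyl)carbonyl or a (4-methylphenyl)sulfonyl group on the same nitrogen would divide them. Also open, from the compounds shown here alone, is whether any group at this position, such as a (4-chlorophenyl)sulfonyl or a (4-methoxyphenyl)sulfonyl group, can bring the number below that of compound 1 at 2190 nM.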